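Methoxy for Methyl: Expecting Little Change

A few compounds are considered here, and "the series" means these few. Any claim that something is new, unique, unknown or untested is made for them only; others in the source may bear on it.

Compound 1 `COc1cccc2cc(-c3ccc(Br)nn3)c(=O)oc12`: 12900 nM
Compound 2 `Cc1cccc2cc(-c3ccc(Cl)nn3)c(=O)oc12`: 22700 nM

Both numbers come from an assay on cells for inhibition of Amine oxidase [flavin-containing] B (Homo sapiens), read by fluorescence and Amplex Red, with a stated time of 15 min; on this read-out lower numbers stand for stronger inhibition and higher numbers for weaker inhibition. Compound 2 stands at the top of these two numbers, yet compound 1 with 12900 nM sits within the usual scatter of it, so the two cannot be told apart. Compound 3 `COc1cccc2cc(-c3ccc(Cl)nn3)c(=O)oc12` differs from compound 2 by methoxy in place of methyl on an aromatic carbon. Within the data shown here, no measured pair shows this change on its own, so its effect is unknown, and in this assay a step of no size beyond the scatter is expected. Compound 3 is estimated at 15000 nM, with a range from 6000 nM to 38000 nM. The expected step is a 1.5-fold lower number from compound 2 to compound 3 (0.18 log units; within the scatter).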

Compound 3, half-maximal inhibitory concentration: 30100 nM
The estimate for compound 3 lay 2.0-fold (0.30 log units) below the measured number, within the range that was stated.
By their numbers in this assay, from the lowest: compounds 1, 2 and 3 (each within the scatter of the next, the first and the last beyond it).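

In this assay, methoxy in place of methyl on this aromatic carbon gives a 1.3-fold higher number from compound 2 to compound 3 (0.12 log units; within the scatter) and so no change that can be told apart from ordinary scatter. Among these compounds, this is the first direct reading of that swap at this position. With the methoxy group kept, chloro in place of bromo on an aromatic carbon gives a 2.3-fold higher number from compound 1 to compound 3 (0.37 log units; beyond the scatter) and thus a modest but readable change.

As far as these compounds go, whether an amine or a longer chain on this same carbon would shift the number remains open. The reason for either step also remains open, as nothing measured here bears on it.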